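Chloro in place of methoxy: notes on compound 4

The source may hold more compounds than are shown below. What is called first, only, known or untested is meant among the compounds shown, and "the series" means these compounds.

Measured so far in a physicochemical assay for lipophilicity, at pH 7.4; on this read-out lower numbers stand for lower lipophilicity and higher numbers for higher lipophilicity:
- compound 1 (`COc1ccc(C2CCc3nc[nH]c3C2)cc1`) reads 2.6
- compound 2 (`COc1cccc(C2CCc3nc[nH]c3C2)c1`) reads 2.6
- compound 3 (`NC(=O)c1ccccc1C1Cc2nccn2C1`) reads "not determined" (no result reported)

Level with compound 1, compound 2 stands at 2.6 on this scale, and the two values lie within the usual scatter of each other. Within the data shown here, compound 3 offers no number for comparison, so compound 1 is the only measured neighbour of compound 2.

The next compound to be measured is compound 4 (`Clc1cccc(C2CCc3nc[nH]c3C2)c1`). It follows from compound 2 by one exchange, chloro in place of methoxy on an aromatic carbon of a six-membered aromatic ring of carbon only: chloro in place of methoxy on an aromatic carbon. The rest of the structure stays the same.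

Among the measured compounds shown here, the measured compounds contain no step for this exchange, so the expectation rests on the structural change alone and carries more uncertainty than a measured step would. A moderate move to a higher number in this assay is expected, larger than the usual scatter. The expected step of a number 0.60 log units higher from compound 2 to compound 4 (beyond the scatter) is upward. For compound 4 the estimate is 3.2 with an expected range of 2.8 to 3.6 on this read-out.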

Compound 4, distribution coefficient: 3.3
Compound 4: the middle estimate sits 0.10 log units below what was measured, within the range that was stated.
By their numbers in this assay, from the lowest: compounds 1 and 2 (each within the scatter of the next); then compound 4.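

In this assay, among these compounds, chloro in place of methoxy on an aromatic carbon gives a number 0.70 log units higher from compound 2 to compound 4 (beyond the scatter) and is the first step to lie beyond the scatter. The two earlier measured compounds both carry methoxy and stand level, so only now does the read-out separate two compounds, and the group on this aromatic carbon, meta to a group of 9 heavy atoms, proves to be one place where the number can move with the rest of the structure unchanged. No supporting measurement is available to say why the number moves, so this single pair records the size and direction of the change and nothing about its origin.

On these data alone, whether other groups on this carbon, such as trifluoromethyl, a nitrile, an amine or a carboxylic acid, would shift the number as far, or in the same direction, remains open, as does the effect of a longer chain such as ethoxy. Also open, as far as these compounds go, is whether chloro in place of the methoxy of compound 1 would give a step of similar size, since one pair cannot establish a trend across the series.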